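The source may report more compounds than this note shows. Statements on the series, on what has been measured and on what is new or still open speak of the compounds shown alone.

Compound 1 `C/C(CN(C[C@H]1Cc2ccccc2CN1)[C@H]1CCCc2cccnc21)=C(/F)CN` gives 1800 nM in a functional assay on CCRF-CEM cells for antagonist activity at C-X-C chemokine receptor type 4 (Homo sapiens), read by calcium flux, with stated times of 25 min and 90 s; on this read-out lower numbers stand for stronger inhibition and higher numbers for weaker inhibition.
Compound 2 `NC[C@H]1CC[C@H](CN(C[C@H]2Cc3ccccc3CN2)[C@H]2CCCc3cccnc32)CC1` gives 340 nM in this assay.
Compound 3 `C/C(CN(C[C@H]1Cc2ccccc2CN1)[C@H]1CCCc2cccnc21)=C(\F)CN` gives 80 nM in this assay.

Compound 3 stands lowest of the three in this assay, with compound 2 nearest to it and compound 1 furthest. The step from compound 2 to compound 3 is a 4.3-fold lower number from compound 2 to compound 3 (0.63 log units; beyond the scatter); the step from compound 1 to compound 3 is a 23-fold lower number from compound 1 to compound 3 (1.35 log units; beyond the scatter), resting on (the fact that compounds 1 and 3 differ only in the configuration as drawn).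

Compound 4 `N[C@H]1CC[C@@H](N(C[C@H]2Cc3ccccc3CN2)[C@H]2CCCc3cccnc32)CC1` is not yet measured. It differs from compound 3 by 4-aminocyclohexyl in place of 4-amino-3-fluoro-2-methylbut-2-en-1-yl on an amine nitrogen. For the measured compounds named here, of the measured steps, the one from compound 2 to compound 3 bears most directly on this change, since it too exchanges a cyclohexyl-bearing group for the fluoro-alkene; compound 4 goes back to a saturated ring, here bound directly to the amine nitrogen, whereas compound 2 carries 4-(aminomethyl)cyclohexyl. The step from compound 1 to compound 3 concerns only the geometry of the fluoro-alkene and says little about a ring. The step from compound 3 to compound 4 in this assay is therefore expected to be a 6.3-fold higher number from compound 3 to compound 4 (0.80 log units; beyond the scatter), running opposite to a 4.3-fold lower number from compound 2 to compound 3 (0.63 log units; beyond the scatter). Compound 4 is estimated at 500 nM, between 150 nM and 2000 nM.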

Compound 4, half-maximal inhibitory concentration: 1800 nM
Beside the measured number, compound 4's estimate is 3.6-fold (0.56 log units) below it, within the range that was stated.
By their numbers in this assay, from the lowest: compound 3; then compound 2; then compounds 1 and 4 (each within the scatter of the next).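

On the amine nitrogen, 4-aminocyclohexyl in place of 4-amino-3-fluoro-2-methylbut-2-en-1-yl proves costly in this assay, with a 23-fold higher number from compound 3 to compound 4 (1.35 log units; beyond the scatter). A ring alone therefore does not carry this position, for the shorter 4-aminocyclohexyl also gives up ground against the (4-(aminomethyl)cyclohexyl)methyl group, with a 5.3-fold higher number from compound 2 to compound 4 (0.72 log units; beyond the scatter). Against the other alkene geometry there is no change at the digits printed from compound 1 to compound 4 (within the scatter), so the ring compound sits level only with the weaker of the two alkene isomers, a gap that rests on configuration alone: the fact that compounds 1 and 3 differ only in the configuration as drawn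

From the compounds shown here alone, what 4-aminocyclohexylmethyl or 4-(aminomethyl)cyclohexyl would give on the same nitrogen stays open. The parts of the difference between compound 2 and compound 4 therefore cannot yet be told apart.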